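From 2-methoxyethyl to (thiophen-2-yl)methyl in K562 cells

This account rests on a few compounds, and the source may have more. Where it says the series, first, only, none or still open, it means among the compounds named here.

In a functional assay on K562 cells (Homo sapiens) for antiproliferative activity, read by CellTiter-Glo, with a stated time of 72 h (on this read-out higher numbers stand for an effect only at larger amounts of compound and lower numbers for an effect already at smaller amounts), compound 3, `COCCNc1ncnc2c1ncn2[C@@H]1O[C@H](COS(N)(=O)=O)[C@@H](O)[C@H]1O`, reads > 1000 nM, which is a limit and not a number. Compound 1, `CC(C)(C)CC(C)(C)Nc1ncnc2c1ncn2[C@@H]1O[C@H](COS(N)(=O)=O)[C@@H](O)[C@H]1O`, reads > 1000 nM, also a limit. Two of the three measured compounds therefore sit at the limit of > 1000 nM in this assay, at which 2 of the 3 values shown sit. Only compound 2, `CCCCCC(C)Nc1ncnc2c1ncn2[C@@H]1O[C@H](COS(N)(=O)=O)[C@@H](O)[C@H]1O`, gives a number, 203 nM.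

Compound 4, `NS(=O)(=O)OC[C@H]1O[C@@H](n2cnc3c(NCc4cccs4)ncnc32)[C@H](O)[C@@H]1O`, carries thiophen-2-yl in place of methoxymethyl on a saturated chain carbon bound to a nitrogen on an aromatic ring. Read one bond further out, this is (thiophen-2-yl)methyl in place of 2-methoxyethyl.

Three measured steps change the same substituent. The clearest for compound 3 is an at least 4.9-fold higher number from compound 2 to compound 3 (0.69 log units; beyond the scatter). The step of an at least 4.9-fold lower number from compound 1 to compound 2 (0.69 log units; beyond the scatter) shows that compound 2 also stands apart from compound 1, while a step that the two limits leave unreadable from compound 1 to compound 3 says nothing about size. These steps show that the group on this nitrogen can move the result, but none of them introduces a ring, so they transfer only loosely. A modest shift towards a lower number is expected, and compound 4 may yet stay at the limit. The expected step is an at least 1.6-fold lower number from compound 3 to compound 4 (0.22 log units; that floor lies within the scatter). For compound 4 the estimated value is 600 nM, within an expected range of 150 nM to 2500 nM.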

Compound 4, half-maximal effective concentration: 114 nM
Compound 4: middle estimate off by 5.3-fold (0.72 log units), on the high side; measured number below the stated range.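

In this assay, the step of an at least 8.7-fold lower number from compound 3 to compound 4 (0.94 log units; beyond the scatter) shows that thiophen-2-yl in place of methoxymethyl, on a saturated chain carbon bound to a nitrogen on an aromatic ring, moves the result beyond the scatter, and this is the first change shown at this position that brings in a ring. The step of a 1.8-fold lower number from compound 2 to compound 4 (0.25 log units; within the scatter) means that the (thiophen-2-yl)methyl group and the 1-methylhexyl group cannot be told apart here, so a measurable value on this shared core is no longer tied to the open chain of compound 2. The step of an at least 8.7-fold lower number from compound 1 to compound 4 (0.94 log units; beyond the scatter) sets the new group apart from 1,1,3,3-tetramethylbutyl as well, though this step and the one from the 2-methoxyethyl compound give only a floor on their size: the limit of > 1000 nM in this assay, at which 2 of the 4 values shown sit.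

The compounds shown leave open whether the sulfur of the ring matters or any five-membered aromatic ring would serve, which a (furan-2-yl)methyl group on the same nitrogen could test, and whether a benzyl group would read the same. They also leave open whether a 2-(thiophen-2-yl)ethyl group, with the ring one carbon further out, would keep the value.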